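Working notes: removal of the ring-nitrogen acetyl, compound 2 to compound 3

A few compounds are considered here, and "the series" means these few. Any claim that something is new, unique, unknown or untested is made for them only; others in the source may bear on it.

Measured so far:
Compound 1, `COc1ccc(NC(=O)c2ccc3ccccc3n2)cc1`, gives 7650 nM in a functional assay on NCI-H23 cells (Homo sapiens) for cytotoxicity, read by sulforhodamine B assay, with a stated time of 72 h; on this read-out higher numbers stand for weaker inhibition of growth and lower numbers for stronger inhibition of growth.
Compound 2, `CC(=O)N1c2ccccc2CCC1C(=O)Nc1cc(C(F)(F)F)cc(C(F)(F)F)c1`, is recorded only as a limit of this assay, not a number: > 70000 nM.

Of the two measured entries, compound 2 is the one that sits at the limit, as stated in the limit of > 70000 nM in this assay, at which 1 of the 2 values shown sits, while compound 1 returns a measured number. Among the compounds with values here, no pair of measured compounds differs in one place, so no measured step exists for orientation.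

Compound 3, `O=C(Nc1cc(C(F)(F)F)cc(C(F)(F)F)c1)C1CCc2ccccc2N1`, differs from compound 2 by hydrogen in place of acetyl on a nitrogen on an aromatic ring in a ring. With compound 2 known only as a limit, any direction for this change is an expectation, not a reading. The expected step of an at least 1.4-fold lower number from compound 2 to compound 3 (0.14 log units; that floor lies within the scatter) is taken as none beyond the usual scatter. Compound 3 is therefore estimated at 50000 nM, within 8000 nM to 150000 nM, and a further limit rather than a number is considered likely.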

Compound 3, concentration for 50% growth inhibition: 8410 nM
Compound 3: middle estimate off by 5.9-fold (0.77 log units), on the high side; the range from low to high includes it.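

With hydrogen in place of acetyl on the ring nitrogen, this assay shows an at least 8.3-fold lower number from compound 2 to compound 3 (0.92 log units; beyond the scatter). Within the data shown here, this is the first step read at this position, and it shows that the nitrogen's substituent alone can separate a measured number from a limit on this core. Compound 2 is recorded only as a limit, not a number, so the size of the step is a floor and its true extent stays unknown: the limit of > 70000 nM in this assay, at which 1 of the 3 values shown sits.

The compounds shown leave open whether a methyl group or another small alkyl group on this nitrogen would give a number close to that of compound 3 or return to the limit. They also leave open whether the whole acetyl group or only its carbonyl accounts for the step, a question that an ethyl group on the same nitrogen could address.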